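Benzyl in Place of Phenyl on the Amide Nitrogen

The source may hold more compounds than are shown below. What is called first, only, known or untested is meant among the compounds shown, and "the series" means these compounds.

Within the data shown here, compound 1 `O=C(Nc1ccccc1)C1CCN(C/C=C/c2ccccc2)CC1` gives 69700 nM in a functional assay on A549 cells (Homo sapiens) for inhibition, read by MTT assay, with a stated time of 72 h (a lower number here means a stronger inhibitor, a higher number a weaker inhibitor), the highest of the two numbers measured so far; compound 2 `CCCc1ccc(NC(=O)C2CCN(C/C=C/c3ccccc3)CC2)cc1` gives 9470 nM. Among the measured compounds shown here, the one measured step, a 7.4-fold lower number from compound 1 to compound 2 (0.87 log units; beyond the scatter), alters an aromatic carbon rather than the amide nitrogen. Compound 3 `O=C(NCc1ccccc1)C1CCN(C/C=C/c2ccccc2)CC1` differs from compound 1 by benzyl in place of phenyl on an amide-type nitrogen. For the measured compounds named here, no measured step bears on this change, so nothing beyond the scatter is expected in this assay. Compound 3 is therefore estimated at 50000 nM, with a range of 15000 nM to 150000 nM. The expected step is a 1.4-fold lower number from compound 1 to compound 3 (0.14 log units; within the scatter).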

Compound 3, half-maximal inhibitory concentration: > 100000 nM
Compound 3: no number, only a limit (the forecaster's own chance of this, stated with the estimate: 15%); at least 2.0-fold (0.30 log units) between middle value and limit.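

Compound 3 reaches only a limit of the assay, not a number: the limit of > 100000 nM in this assay, at which 1 of the 3 values shown sits. Benzyl in place of phenyl gives an at least 1.4-fold higher number from compound 1 to compound 3 (0.15 log units; that floor lies within the scatter), so in this assay this change on the amide-type nitrogen brings no gain over the anilino group, though the true size of the step remains unknown. Benzyl in place of 4-propylphenyl gives an at least 10-fold higher number from compound 2 to compound 3 (1.02 log units; beyond the scatter), so the lower number of the propyl compound does not survive this change. From the compounds shown here alone, whether 4-propylbenzyl or phenethyl on the amide-type nitrogen would return a measurable number stays open.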